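Pyrrolidin-1-yl to piperidin-1-yl on the thiocarbonyl carbon

The source may hold more compounds than are shown below. What is called first, only, known or untested is meant among the compounds shown, and "the series" means these compounds.

Compound 1 `O=c1c(CSC(=S)N2CCCC2)coc2ccccc12`: in a functional assay on MCF7 cells (Homo sapiens) for antiproliferative activity, read by MTT assay, with a stated time of 72 h (a higher number here means a weaker inhibitor, a lower number a stronger inhibitor), compound 1 gives > 25000 nM, a limit of the assay.
Compound 2 `O=c1c(CSC(=S)N2CCCC2)coc2cc(Cl)ccc12`: in this assay compound 2 gives 600 nM.

Compound 1 stands only at a limit in this assay, so its true value is not known (the limit of > 25000 nM in this assay, at which 1 of the 2 values shown sits). Compound 3 `O=c1c(CSC(=S)N2CCCCC2)coc2ccccc12` differs from compound 1 in one place: piperidin-1-yl in place of pyrrolidin-1-yl on a thiocarbonyl carbon. Within the data shown here, the only measured step, an at least 41-fold lower number from compound 1 to compound 2 (1.61 log units; beyond the scatter), concerns chloro in place of hydrogen on an aromatic carbon and does not touch the thiocarbonyl carbon, so it gives no guide to this change. No step beyond the scatter is expected in either direction, and compound 3 is estimated at 25000 nM (range 8000 nM to 80000 nM), an expected step of a number no higher from compound 1 to compound 3 (the limit leaves the size open), most likely again only a limit.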

Compound 3, half-maximal inhibitory concentration: 1700 nM
For compound 3 the middle estimate is 15-fold (1.17 log units) above the measured one; measured number outside the range, below it.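

In this assay, piperidin-1-yl in place of pyrrolidin-1-yl on the thiocarbonyl carbon gives an at least 14-fold lower number from compound 1 to compound 3 (1.16 log units; beyond the scatter). The amine ring on this carbon, untouched by the earlier pair, is therefore a second place where a single change on the shared core moves the number beyond the scatter. Compound 1 stands at a limit, so the size of this step stays open: the limit of > 25000 nM in this assay, at which 1 of the 3 values shown sits.

From the compounds shown here alone, whether chloro and piperidin-1-yl combined on the shared core go further than either change alone remains open. Also open, going by these compounds, is whether a morpholin-4-yl ring or an open-chain diethylamino group on the thiocarbonyl carbon would give a similar step.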